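The compounds below may be only part of what the source reports. "The series", "measured", "known", "first", "only" and "open" are said of these compounds alone.

Measured compounds:
- compound 1, `CCCSc1nc(N/N=C(\C)c2ccc(OC)cc2)c2nnn(Cc3ccccc3)c2n1` — in a functional assay on ECa-109 cells (Homo sapiens) for antiproliferative activity, read by MTT assay, with a stated time of 72 h (a higher number here means a weaker inhibitor, a lower number a stronger inhibitor), compound 1 gives > 64000 nM, which is a limit of the assay rather than a number.
- compound 2, `CCCSc1nc(N/N=C/c2cccc(Cl)c2)c2nnn(Cc3ccccc3)c2n1` — in this assay compound 2 gives > 64000 nM, again a limit of the assay and not a number.

Compound 2 therefore stands at the edge of what this assay can report: only a limit is known for it, and the other value shown is a limit too. This is summed up by the limit of > 64000 nM in this assay, at which 2 of the 2 values shown sit. No numbered value exists for either compound. No measured step between them can be drawn, and nothing in the shown values separates one from the other.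

Compound 3, `CCCSc1nc(N/N=C/c2ccccc2F)c2nnn(Cc3ccccc3)c2n1`, keeps the shared core of compound 2 and differs in a single place: 2-fluorophenyl in place of 3-chlorophenyl on a carbon with a double bond to nitrogen. With both measured compounds at the same limit, the expectation for compound 3 in this assay is no step beyond the usual scatter, in either direction. The estimated step from compound 2 to compound 3 is therefore a step that the limit leaves unreadable from compound 2 to compound 3. Compound 3 is expected to give about 80000 nM, within a range of 20000 nM to 300000 nM, most likely reported as a limit again.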

Compound 3, half-maximal inhibitory concentration: > 64000 nM
Compound 3 gave a limit, no number; the forecaster's own chance of this, stated with the estimate: 85%; the middle value does not contradict the limit.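

Compound 2 and compound 3 both end at a limit of the assay rather than a number, so no step between them can be read in this assay from what is shown: the limit of > 64000 nM in this assay, at which 3 of the 3 values shown sit.

What stays open is how strongly any of these compounds acts, and whether any change to the shared core would give a real number instead of a limit.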